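A few compounds are considered here, and "the series" means these few. Any claim that something is new, unique, unknown or untested is made for them only; others in the source may bear on it.

Series notes. Among the measured compounds shown here, compound 2 `CS(=O)(=O)c1cc(C(=O)N=C(N)N)ccc1Oc1cccnc1` gives 76 nM in a functional assay for inhibition of sodium/hydrogen exchanger (Oryctolagus cuniculus) (a lower number here means a stronger inhibitor, a higher number a weaker inhibitor), and stands second highest of the three numbers measured so far. Compound 1 `Cc1c(C(=O)N=C(N)N)ccc(Oc2cccnc2)c1S(C)(=O)=O` gives 2200 nM, and compound 3 `Cc1cc(Oc2cccnc2)c(S(C)(=O)=O)cc1C(=O)N=C(N)N` gives 8.8 nM. Both measured steps concern a methyl on an aromatic carbon: a 29-fold lower number from compound 1 to compound 2 (1.46 log units; beyond the scatter) and an 8.6-fold lower number from compound 2 to compound 3 (0.94 log units; beyond the scatter). Compound 4 `CS(=O)(=O)c1cc(C(=O)N=C(N)N)ccc1-n1ccc(=O)cc1` differs from compound 2 by a group of 7 heavy atoms (5 carbon, 1 nitrogen, 1 oxygen; one six-membered aromatic ring with 1 hetero atom) in place of a group of 7 heavy atoms (5 carbon, 1 nitrogen, 1 oxygen; one six-membered aromatic ring with 1 hetero atom), on an aromatic carbon. For the measured compounds named here, neither measured step touches this part of the structure, so no step bears directly on it; the change rearranges the same atoms, and its effect in this assay cannot be read from the series. With wide uncertainty, compound 4 is expected to show a step of a 2.6-fold higher number from compound 2 to compound 4 (0.42 log units; beyond the scatter), most likely toward a higher number. Compound 4 is estimated at 200 nM, range 30 nM to 1500 nM.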

Compound 4, half-maximal inhibitory concentration: 710 nM
Compound 4: the middle estimate sits 3.6-fold (0.55 log units) below what was measured; measured number inside the range.
By their numbers in this assay, from the lowest: compound 3; then compound 2; then compound 4; then compound 1.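

In this assay, replacing the (pyridin-3-yl)oxy group with the differently joined group of compound 4 gives a 9.3-fold higher number from compound 2 to compound 4 (0.97 log units; beyond the scatter) and so shows that this position, untouched by the methyl steps, responds to how the same atoms are connected. Matching counts of heavy atoms, hydrogen-bond donors and hydrogen-bond acceptors do not hold the number in place here. No measurement at hand accounts for this step. Still open, going by these compounds, is how a phenoxy group or a simple amine on this carbon would compare with compound 2. Also open, on these data alone, is whether the added methyl of compound 3 would lower the number with the group of compound 4 in place.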